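Replacing one aromatic group in compound 2

The source may hold more compounds than are shown below. What is called first, only, known or untested is meant among the compounds shown, and "the series" means these compounds.

- compound 1 `CC[C@](C)(CCCC(C)C)CCc1ccc(O)c(I)c1` gives 8%
- compound 2 `COc1ccccc1/C=C/[C@@](C)(/C=C/c1ccc(O)cc1)CCC=C(C)C` gives 46%

In a functional assay on PC-3 cells (Homo sapiens) for inhibition, with a stated time of 48 h, tested at 50 uM (a lower number here means less inhibition of growth, a higher number more inhibition of growth at the concentration tested), compound 2 stands at 46% and is the higher of the two, with compound 1 at 8% and a gap beyond the usual scatter. These two compounds differ in more than one place, so their gap cannot be tied to any single group.

Compound 3 `CC(C)=CCC[C@@](C)(/C=C/c1ccc(N)cc1)/C=C/c1ccc(O)cc1` has not yet been measured and differs from compound 2 in one place (4-aminophenyl in place of 2-methoxyphenyl on a double-bonded chain carbon bound to a double-bonded chain carbon): 4-aminophenyl in place of 2-methoxyphenyl on a double-bonded chain carbon bound to a double-bonded chain carbon.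

Going by the values given here, no measured pair of compounds shows what this swap does, and two compounds offer little to go on. The reasoning therefore starts from compound 2 at 46% and expects no clear change. The expected step of a number 1 percentage points lower from compound 2 to compound 3 (within the scatter) lies within the scatter, with neither direction favoured. In this assay compound 3 is expected at 45% with 22% to 68% as its estimated range.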

Compound 3, percent growth inhibition at one concentration: 59%
Compound 3: middle estimate off by 14 percentage points, on the low side, within the range that was stated.
By their numbers in this assay, from the lowest: compound 1; then compound 2; then compound 3.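

In this assay, putting 4-aminophenyl in place of 2-methoxyphenyl on a double-bonded chain carbon bound to a double-bonded chain carbon gives a number 13 percentage points higher from compound 2 to compound 3 (beyond the scatter), a modest step and the first gap in this set that can be tied to a single place. It shows that the aromatic group at this position can alter growth inhibition at the concentration tested, and that 4-aminophenyl is the better of the two groups compared here. No measurement shown explains why the step occurs.

The names of the two groups show that two things change together, the group on the phenyl ring and its numbered place, so the compounds shown leave open which of them carries the step; a 4-methoxyphenyl or a 2-aminophenyl at this position would separate the two. Also open, from the compounds shown here alone, is whether the free amine itself matters, which a 4-acetamidophenyl or a 4-(dimethylamino)phenyl group at the same position would test.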